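This account rests on a few compounds, and the source may have more. Where it says the series, first, only, none or still open, it means among the compounds named here.

The step from compound 1 to compound 4 begins without a number for its starting point: compound 1 is recorded in a functional assay on HCT-116 cells (Homo sapiens) for inhibition, read by MTT assay, with a stated time of 72 h (on this read-out lower numbers stand for stronger inhibition of growth and higher numbers for weaker inhibition of growth), only as "not determined" (no result reported). Compound 1, `CC(C)[C@@H](NC(=O)/C=C/c1ccncc1-c1ccc2ccccc2c1)C(=O)O`, thus has no result in this assay; compound 3, `O=C(/C=C/c1ccncc1-c1ccc2ncccc2c1)N1CCOCC1`, likewise shows none, being recorded in this assay as "not determined" (no result reported). Going by the values given here, the single number comes from compound 2, `CNC(=O)/C=C/c1ccncc1-c1ccc2c(ccn2C)c1`, which in this assay gives 4450 nM. Compound 1 therefore stands nowhere on the numbers shown, and no step between two measured compounds exists to calibrate what a change of this kind does.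

Compound 4, `CCOC(=O)/C=C/c1ccncc1-c1ccc2ccccc2c1`, differs from compound 1 in one place: ethoxy in place of (1-carboxy-2-methylpropyl)amino on a carbonyl carbon. Among the compounds with values here, since no measured step is available, the direction of this change in this assay cannot be drawn from the data, and no step beyond the usual scatter is assumed in either direction. Within the data shown here, the only anchor is compound 2, whose value of 4450 nM suggests the general level at which this core appears. On that basis compound 4 is expected to give roughly 5000 nM in this assay, with a plausible range from 1200 nM to 25000 nM.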

Compound 4, concentration for 50% growth inhibition: 910 nM
Beside the measured number, compound 4's estimate is 5.5-fold (0.74 log units) above it; measured number outside the range, below it.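

Going by these compounds alone, compound 1 is recorded as "not determined" (no result reported) in this assay, so no step to compound 4 can be read from this pair. No evidence is available that bears on the result for compound 4. As far as these compounds go, whether ethoxy in place of (1-carboxy-2-methylpropyl)amino on the carbonyl carbon strengthens or weakens growth inhibition stays open.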